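The source may hold more compounds than are shown below. What is called first, only, known or untested is meant among the compounds shown, and "the series" means these compounds.

Measured so far:
compound 1, `Cc1ccc(F)cc1NC(=O)CN1CCN(c2nnc(Cc3ccccc3)c3ccccc23)CC1`: 171000 nM
compound 2, `O=C(CN1CCN(c2nnc(Cc3ccncc3)c3ccccc23)CC1)Nc1ccc(F)c(C(F)(F)F)c1`: 1110 nM
compound 3, `Cc1ccc(F)cc1NC(=O)CN1CCN(c2nnc(Cc3ccncc3)c3ccccc23)CC1`: 470 nM

These values come from a functional assay on HT-29 cells (Homo sapiens) for cytotoxicity, read by MTT assay, with a stated time of 72 h; on this read-out higher numbers stand for weaker inhibition and lower numbers for stronger inhibition. Compound 1 has the highest number of the three, the weakest inhibition. Compound 4, `Cc1ccc(NC(=O)CN2CCN(c3nnc(Cc4ccccc4)c4ccccc34)CC2)c(C)c1`, is not yet measured; it differs from compound 1 in one place: 2,4-dimethylphenyl in place of 5-fluoro-2-methylphenyl on an amide-type nitrogen. The change sits on the amide-type nitrogen, the same place where the change between compound 2 and compound 3 sits; that step was a 2.4-fold lower number from compound 2 to compound 3 (0.37 log units; beyond the scatter), modest. The large step of a 360-fold lower number from compound 1 to compound 3 (2.56 log units; beyond the scatter) concerns a different place, which compound 4 keeps as in compound 1. So only a small step, in either direction, is expected: a 1.1-fold lower number from compound 1 to compound 4 (0.06 log units; within the scatter). Compound 4 is therefore estimated at 150000 nM, within 50000 nM to 400000 nM.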

Compound 4, half-maximal inhibitory concentration: "not active" (no number reported)
Nothing numeric was reported for compound 4; no gap can be computed for the estimate.
By their numbers in this assay, from the lowest: compound 3; then compound 2; then compound 1.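

In this assay, going by these compounds alone, compound 4 is reported only as not active, without a number, so no step from compound 1 to compound 4 can be read. Nothing measured here offers an explanation for this result. The compounds shown leave open how far 2,4-dimethylphenyl in place of 5-fluoro-2-methylphenyl shifts the number.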